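This account rests on a few compounds, and the source may have more. Where it says the series, first, only, none or still open, it means among the compounds named here.

Of the compounds shown here, three have been tested in a functional assay on EKVX cells (Homo sapiens) for inhibition, read by sulforhodamine B assay, with a stated time of 48 h (a lower number here means that less compound is tolerated, a higher number that more compound is tolerated), and none of them has returned a plain number. Compound 1 `CCOC(=O)[C@H](CCC(=O)O)NC(=O)c1ccc(CNc2nc3cc(N)cc(N)c3nc2-c2ccccc2)cc1` gives a value that is a limit of the assay rather than a measurement, < 100000 nM. Compound 2 `Nc1cc(N)c2nc(-c3ccccc3)c(NCc3ccc(Cl)c(Cl)c3)nc2c1` likewise gives only a limit, < 100000 nM. Compound 3 `CCOC(=O)[C@H](CCC(=O)O)NC(=O)c1ccc(Sc2nc3cc(N)cc(N)c3nc2-c2ccccc2)cc1` too gives only a limit, < 100000 nM. Compound 2 therefore stands where every measured compound stands, namely at the limit of < 100000 nM in this assay, at which 3 of the 3 values shown sit, with nothing that sets it apart from the other two.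

Compound 4 `COc1ccc(CNc2nc3cc(N)cc(N)c3nc2-c2ccccc2)cc1` has not yet been measured in this assay. It differs from compound 2 in one place: 4-methoxyphenyl in place of 3,4-dichlorophenyl on a saturated chain carbon bound to a nitrogen on an aromatic ring. Among the measured compounds shown here, no pair of measured compounds shows what such a change does here, and since the three values are all limits, no step size can be read from them at all. The expected step from compound 2 to compound 4 is accordingly none beyond the scatter, a step that the limit leaves unreadable from compound 2 to compound 4. Compound 4 is estimated at 40000 nM, within a range from 8000 nM to 150000 nM, and most likely the assay will once more report only a limit.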

Compound 4, concentration lethal to 50% of the cells: 53700 nM
Compound 4: middle estimate off by 1.3-fold (0.13 log units), on the low side; the measured number falls inside the stated range.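

Compound 2 gives only a limit of the assay rather than a number, so no step from it to compound 4 can be read: the limit of < 100000 nM in this assay, at which 3 of the 4 values shown sit.

The compounds shown leave open how far 4-methoxyphenyl in place of 3,4-dichlorophenyl actually shifts the result in this assay.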